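The compounds below may be only part of what the source reports. "The series", "measured", "known", "first", "only" and "open" are said of these compounds alone.

Measured so far:
compound 1, `Fc1ccc(-c2nn3ccc(NC4CCCC4)cc3c2-c2ccnc(NC3CCCC3)n2)cc1`: 18000 nM
compound 2, `CC(C)Nc1ccn2nc(-c3ccc(F)cc3)c(-c3ccnc(NC4CCCC4)n3)c2c1`: > 40000 nM

Among the compounds with values here, in an ADME assay on Vero cells (Chlorocebus sabaeus) for cytotoxicity (a higher number here means that more compound is tolerated, a lower number that less compound is tolerated), compound 1 gives 18000 nM, the only plain number in the pair. For compound 2 the value > 40000 nM is a limit of the assay and not a number. Within the data shown here, the single measured step runs an at least 2.2-fold higher number from compound 1 to compound 2 (0.34 log units; beyond the scatter); its size rests on (the limit of > 40000 nM in this assay, at which 1 of the 2 values shown sits).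

Compound 3, `c1cc(-c2c(-c3ccc(OCC4CC4)cc3)nn3ccc(NC4CCCC4)cc23)nc(NC2CCCC2)n1`, differs from compound 1 in cyclopropylmethoxy in place of fluoro on an aromatic carbon. This exchange sits on a different part of the shared core than the measured step, which concerns the group on a nitrogen on an aromatic ring. Among the measured compounds shown here, the measured step therefore does not bear directly on the new one; it shows only that one change at the periphery of the shared core moved the tolerated concentration beyond the scatter. For the measured compounds named here, no measured step covers an exchange at the aromatic carbon. The expectation for compound 3 is therefore a step within the scatter, no change at the digits printed from compound 1 to compound 3 (within the scatter). The estimate for compound 3 is 18000 nM, with a range from 7000 nM to 40000 nM, and a fair chance that only a limit is returned.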

Compound 3, half-maximal cytotoxic concentration: > 40000 nM
Compound 3 ended at the assay's limit; the forecaster's own chance of this, stated with the estimate: 30%; middle value at least 2.2-fold (0.34 log units) from the limit.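

Within the data shown here, at the aromatic carbon para to a large group, the exchange of fluoro for cyclopropylmethoxy gives in this assay the first reading for this position: an at least 2.2-fold higher number from compound 1 to compound 3 (0.34 log units; beyond the scatter). Compound 3 gives > 40000 nM, which is a limit of the assay and not a number. The 4-(cyclopropylmethoxy)phenyl group, with more heavy atoms than 4-fluorophenyl and a three-membered ring, therefore does not lower the tolerated concentration, and a change at this aromatic carbon, like the change on the nitrogen in compound 2, can move the read-out beyond the scatter, while the full size of the step stays unknown: the limit of > 40000 nM in this assay, at which 2 of the 3 values shown sit.

On these data alone, the sizes of the two steps from compound 1 cannot be ranked against each other, and it remains open whether the two exchanges together would differ from either one alone. As far as these compounds go, it also remains open whether methoxy, a longer alkoxy chain, an amine or a carboxylic acid at the same aromatic carbon would give a plain number in this assay or again a limit.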